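Compound 4 and the limit of the series

This account rests on a few compounds, and the source may have more. Where it says the series, first, only, none or still open, it means among the compounds named here.

For the measured compounds named here, in an ADME assay on L02 cells (Homo sapiens) for antiproliferative activity, read by MTT assay, with a stated time of 48 h (a higher number here means a weaker inhibitor, a lower number a stronger inhibitor), compound 1 `CCn1c(C(=O)NCCN)ccc1C(CC)(CC)c1ccc(OCCC(O)(CC)CC)c(C)c1` gives 2940 nM as the only number so far. Compound 2 `C#CC(C)OC(=O)c1ccc(C(CC)(CC)c2ccc(OCCC(O)(CC)CC)c(C)c2)n1CC` reads > 50000 nM and this is a limit of the assay. Compound 3 `CCC(C)C(NC(=O)c1ccc(C(CC)(CC)c2ccc(OCCC(O)(CC)CC)c(C)c2)n1CC)C(=O)OC` reads > 50000 nM and this too is a limit, not a number. It therefore stands at the limit of > 50000 nM in this assay, at which 2 of the 3 values shown sit, and gives no exact starting point.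

Compound 4 `CCn1c(C(=O)N(C)CC(=O)O)ccc1C(CC)(CC)c1ccc(OCCC(O)(CC)CC)c(C)c1` brings (carboxymethyl)(methyl)amino onto a carbonyl carbon (a group of 6 heavy atoms (3 carbon, 1 nitrogen, 2 oxygen; no ring) in place of a group of 10 heavy atoms (7 carbon, 1 nitrogen, 2 oxygen; no ring), on a carbonyl carbon).

Two large steps bear on this: an at least 17-fold higher number from compound 1 to compound 2 (1.23 log units; beyond the scatter) and an at least 17-fold higher number from compound 1 to compound 3 (1.23 log units; beyond the scatter) are both beyond the scatter. Neither compound 2 nor compound 3 keeps the (2-aminoethyl)amino of compound 1, and compound 4 lacks it as well. The comparison a step that the two limits leave unreadable from compound 2 to compound 3 adds nothing on size.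

No readable step is therefore expected in this assay and no direction can be named. The expected step is a number no higher from compound 3 to compound 4 (the limit leaves the size open) on this estimate. For compound 4 the estimated value is 50000 nM with an expected range of 15000 nM to 120000 nM and a report as a limit is likely.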

Compound 4, half-maximal inhibitory concentration: 2150 nM
Beside the measured number, compound 4's estimate is 23-fold (1.37 log units) above it; the measured number lies below the stated range.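

In this assay, a number in the low range at this carbonyl carbon does not depend on the (2-aminoethyl)amino of compound 1, since (carboxymethyl)(methyl)amino gives a 1.4-fold lower number from compound 1 to compound 4 (0.14 log units; within the scatter). The same group separates compound 4 from both other compounds, with an at least 23-fold lower number from compound 3 to compound 4 (1.36 log units; beyond the scatter) and an at least 23-fold lower number from compound 2 to compound 4 (1.36 log units; beyond the scatter), so the two compounds with a number end in an amine or a carboxylic acid, while the two without one carry neither. Compound 2 and compound 3 remain limits of the assay, not numbers: the limit of > 50000 nM in this assay, at which 2 of the 4 values shown sit.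

As far as these compounds go, whether the carboxylic acid or the methyl on the amide nitrogen of compound 4 carries this result stays open, and the methyl ester of compound 4 would separate the two. A longer chain, such as (2-carboxyethyl)(methyl)amino, is also untested among the compounds shown.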